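The compounds below may be only part of what the source reports. "The series", "measured", "known", "first", "only" and "open" are said of these compounds alone.

The measurements come from an assay on isolated protein for inhibition of Rho-associated protein kinase 1 (Homo sapiens), read by scintillation counting, radiometric assay and 33P incorporation, with a stated time of 40 min, in the presence of a further agent that is not named here; on this read-out higher numbers stand for weaker inhibition and lower numbers for stronger inhibition. Three compounds share a common core and differ in the groups at its two ends. Compound 1 `COc1ccc(OCC(=O)Nc2cccc(NC(=O)c3ccc(N(C)C)cc3)c2)cc1F` gives 1820 nM. Compound 2 `N#Cc1ccc(C(=O)Nc2cccc(NC(=O)COc3ccc4c(=O)ccoc4c3)c2)cc1` gives 123 nM. Compound 3 `CN(C)c1ccc(S(=O)(=O)Nc2cccc(NC(=O)COc3ccc4c(=O)ccoc4c3)c2)cc1`, which carries a sulfonamide on one side, gives 803 nM. Among these three numbers compound 3 stands second highest: compound 1 sits above it by a gap that lies beyond the usual scatter, and compound 2 sits below it by a larger gap, also beyond the scatter, so compound 2 is the strongest inhibitor of the three.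

Among the measured compounds shown here, compound 4 `O=C(COc1ccc2c(=O)ccoc2c1)Nc1cccc(NS(=O)(=O)c2ccc(OC(F)(F)F)cc2)c1` keeps the whole framework of compound 3 and changes only one group on the sulfonamide ring: trifluoromethoxy in place of dimethylamino on an aromatic carbon. For the measured compounds named here, no pair among the measured compounds shows this change, so there is no step to lean on. For this assay the step from compound 3 to compound 4 is expected to be small, a 1.3-fold lower number from compound 3 to compound 4 (0.13 log units; within the scatter), with either direction possible. Compound 4 is therefore estimated at 600 nM, within a range from 200 nM to 1800 nM.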

Compound 4, half-maximal inhibitory concentration: 6440 nM
For compound 4 the middle estimate is 11-fold (1.03 log units) below the measured one; measured number above the stated range.
By their numbers in this assay, from the lowest: compound 2; then compound 3; then compound 1; then compound 4.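

In this assay, the group on the sulfonamide ring proves to matter: replacing dimethylamino with trifluoromethoxy gives an 8.0-fold higher number from compound 3 to compound 4 (0.90 log units; beyond the scatter), so inhibition weakens clearly with this single change. Among the compounds shown here, the earlier compounds could not show this, since no two of them differed in only one place, and this pair is the first to isolate one group on the ring. No measurement shown explains why this swap weakens inhibition.

A single pair cannot tell whether dimethylamino helps, trifluoromethoxy harms, or both are true; a plain hydrogen, a methoxy group or a diethylamino group at this place would help to separate these possibilities. For the compounds shown here, it also remains open whether the same swap would have a similar effect on an amide-linked ring like the one in compound 2.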